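Pyrazolylpyridine amides: tolerance in macrophages, 4-methoxyphenyl carbonyl variant

The compounds below may be only part of what the source reports. "The series", "measured", "known", "first", "only" and "open" are said of these compounds alone.

The series rests on a shared core carrying a pyridine and an amide; compound 1 `COc1ccc(C(=O)Nc2cc(-c3ccccn3)n[nH]2)cc1` lacks the cyclopropyl that compound 2 `O=C(Nc1[nH]nc(-c2ccccn2)c1C1CC1)c1ccccc1F` carries, and the two also differ in the aryl group on the carbonyl carbon. In an ADME assay on cells (Peritoneal macrophage cell, Mus musculus) for cytotoxicity, read by fluorescence and resazurin assay, with a stated time of 3 days (a higher number here means that more compound is tolerated, a lower number that less compound is tolerated), compound 2 reaches only a limit, > 64000 nM, so its place on the scale is not a number. Compound 1 likewise reaches only a limit, > 40300 nM, in this assay. Both values shown are therefore limits, the limit of > 40300 nM in this assay, at which 1 of the 2 values shown sits, and (the limit of > 64000 nM in this assay, at which 1 of the 2 values shown sits), and neither compound shows measurable toxicity within the tested range.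

Compound 3 `COc1ccc(C(=O)Nc2[nH]nc(-c3ccccn3)c2C2CC2)cc1` follows from compound 2 by the change (4-methoxyphenyl in place of 2-fluorophenyl on a carbonyl carbon). Among the measured compounds shown here, no measured step covers this change, and compound 1, which also carries the 4-methoxyphenyl, gives only > 40300 nM in this assay. The step from compound 2 to compound 3 is expected to be none beyond the scatter, as a number no higher from compound 2 to compound 3 (the limit leaves the size open) in this assay. Compound 3 is expected to give 64000 nM in this assay, with a range from 30000 nM to 150000 nM, most likely again as a limit rather than a number.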

Compound 3, half-maximal cytotoxic concentration: > 64000 nM
Compound 3: no number, only a limit; the forecaster's own chance of this, stated with the estimate: 85%; the middle value sits exactly at the limit.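

Compound 3 again gives only a limit in this assay, so neither its step from compound 2 nor its step from compound 1 can be read: the limit of > 64000 nM in this assay, at which 2 of the 3 values shown sit.

The compounds shown leave open where any of the three sits on the scale of this assay, and whether the 4-methoxyphenyl or the cyclopropyl changes tolerance at all.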